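The compounds below may be only part of what the source reports. "The series", "measured", "known", "first", "only" and "open" are said of these compounds alone.

Measured so far:
- compound 1 `Cc1cccc(NC(=O)N[C@@H](C)c2ccccc2)c1`: 99%
- compound 2 `C[C@H](NC(=O)Nc1cccc(Cl)c1)c1ccccc1`: 103%

In an ADME assay on the whole organism with Oryza sativa as the target, tested at 0.1 uM (on this read-out lower numbers stand for a stronger effect and higher numbers for a weaker effect at the one concentration tested), compound 1 gives 99%, and compound 2 gives 103%. For the measured compounds named here, compound 2 holds the highest of the two numbers, though its only neighbour sits close, and the two values cannot be ordered against each other. Going by the values given here, the single measured step, a number 4 percentage points higher from compound 1 to compound 2 (within the scatter), puts chloro in place of methyl on an aromatic carbon and leaves the read-out essentially where it was.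

Compound 3 `C[C@H](NC(=O)Nc1cccc(Cl)c1Cl)c1ccccc1` is the next member and is not yet measured. It differs from compound 2 by chloro in place of hydrogen on an aromatic carbon. Among the compounds with values here, no measured step touches this exact change; the only step on record, a number 4 percentage points higher from compound 1 to compound 2 (within the scatter), is a swap of one group on that ring and was within the scatter. With both measured numbers lying near full activity and no step beyond the scatter on record, no step beyond the scatter is expected for this added chloro either. For compound 3 the estimate in this assay is 100%, with a range from 86% to 110%, meaning an expected step of a number 3 percentage points lower from compound 2 to compound 3 (within the scatter).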

Compound 3, a percentage reported as activity, at one concentration (the size of the read-out at that concentration, not a potency): 100%
Compound 3: the middle estimate sits on the measured number at the digits printed; measured number inside the range.
By their numbers in this assay, from the lowest: compounds 1, 3 and 2 (each within the scatter of the next).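

In this assay, chloro in place of hydrogen on an aromatic carbon, ortho to a chloro group and ortho to a large group, gives a number 3 percentage points lower from compound 2 to compound 3 (within the scatter) and so leaves no readable change at this position. The earlier step swapped one group for another on this six-membered aromatic ring, whereas this one fills a ring carbon that carried only hydrogen, and it too stays inside the usual variation of the read-out. The added chloro therefore shows that this crowded position can carry a chlorine atom without a readable shift in this assay at the one concentration tested, but nothing available bears on why the number holds there.

From the compounds shown here alone, all the numbers shown sit close together, so it remains open whether any group at this ring carbon, such as an amine, a carboxylic acid or a longer chain, would move the read-out beyond the scatter. Also open, going by these compounds, is whether a fluoro or methoxy group on the other aromatic ring of the core would leave the number equally unmoved.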